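The source may report more compounds than this note shows. Statements on the series, on what has been measured and on what is new or still open speak of the compounds shown alone.

Measured in an assay on isolated protein for inhibition of proto-oncogene tyrosine-protein kinase receptor Ret (Homo sapiens), read by radiometric assay and 33P incorporation, in the presence of a further agent that is not named here; on this read-out lower numbers stand for stronger inhibition and higher numbers for weaker inhibition:
Compound 1 `CC(C)n1nc(-c2cc(C3CCCCC3)on2)c2c(N)ncnc21` gives 910 nM.
Compound 2 `CC(C)n1nc(-c2cc(-c3ccccc3)on2)c2c(N)ncnc21` gives 190 nM.

Within the data shown here, on these numbers compound 2 stands lowest of the two, and the single measured step, a 4.8-fold lower number from compound 1 to compound 2 (0.68 log units; beyond the scatter), lies beyond the scatter. Compound 3 `CC(C)c1cc(-c2nn(C(C)C)c3ncnc(N)c23)no1` differs from compound 2 in one place: isopropyl in place of phenyl on an aromatic carbon. Among the measured compounds shown here, only one measured step bears on this change, and it ran the other way: a 4.8-fold lower number from compound 1 to compound 2 (0.68 log units; beyond the scatter), where the phenyl replaced a cyclohexyl. For the measured compounds named here, compound 3 again trades the phenyl for a group without a ring, so in this assay a step back upward of roughly that size is expected, with the caveat that isopropyl has fewer heavy atoms than cyclohexyl and no measured compound shows what that means here. For compound 3 the expected step is a 4.2-fold higher number from compound 2 to compound 3 (0.62 log units; beyond the scatter), giving an estimate of 800 nM, in the range 300 nM to 2500 nM.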

Compound 3, half-maximal inhibitory concentration: 41 nM
Beside the measured number, compound 3's estimate is 20-fold (1.29 log units) above it; the whole stated range lies above it.
By their numbers in this assay, from the lowest: compound 3; then compound 2; then compound 1.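

In this assay, a ring is not needed on this aromatic carbon next to the ring oxygen for a low number: isopropyl, which has no ring, gives a 4.6-fold lower number from compound 2 to compound 3 (0.67 log units; beyond the scatter) against phenyl and a 22-fold lower number from compound 1 to compound 3 (1.35 log units; beyond the scatter) against cyclohexyl. Phenyl improving on cyclohexyl therefore did not mean that ring-free groups would do worse, and of these three groups, the ring-free one gives the lowest number. Nothing available here explains why this change lowers the number.

The compounds shown leave open how far this trend extends among ring-free groups, such as a methyl, a tert-butyl or a longer chain like n-butyl. They also do not show how a group carrying an amine or a carboxylic acid would behave on this carbon.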